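A methoxyphenyl swap on a triazole-linked terpenoid ester

The compounds below may be only part of what the source reports. "The series", "measured", "known", "first", "only" and "open" are said of these compounds alone.

Compound 1 `C/C(=C\CC/C(C)=C/CC[C@@H]1[C@@]2(C)CCC(=O)C(C)(C)[C@H]2CC[C@@]1(C)O)CC/C=C(\C)C(=O)OCc1cn(-c2ccccc2[N+](=O)[O-])nn1` gives > 150000 nM in a functional assay on A549 cells (Homo sapiens) for antiproliferative activity, read by MTT assay, with a stated time of 48 h (on this read-out lower numbers stand for stronger inhibition and higher numbers for weaker inhibition), and this value is a limit of the assay rather than a number.
Compound 2 `C/C(=C\CC/C(C)=C/CC[C@@H]1[C@@]2(C)CCC(=O)C(C)(C)[C@H]2CC[C@@]1(C)O)CC/C=C(\C)C(=O)OCc1cn(-c2cccc([N+](=O)[O-])c2)nn1` gives > 150000 nM in this assay, again a limit rather than a number.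

Compound 1 therefore stands only at a limit in this assay; no measured number places it more precisely. Within the data shown here, the single measured step, a step that the two limits leave unreadable from compound 1 to compound 2, runs from one limit to another and cannot be read in size or direction, because both values sit at the limit of > 150000 nM in this assay, at which 2 of the 2 values shown sit. Nothing measured here shows any effect of the group on the aromatic nitrogen.

Compound 3 `COc1cccc(-n2cc(COC(=O)/C(C)=C/CC/C(C)=C/CC/C(C)=C/CC[C@@H]3[C@@]4(C)CCC(=O)C(C)(C)[C@H]4CC[C@@]3(C)O)nn2)c1` differs from compound 1 in one place: 3-methoxyphenyl in place of 2-nitrophenyl on an aromatic nitrogen. Among the measured compounds shown here, no measured step involves a 3-methoxyphenyl group, so the only guide for compound 3 is that compound 1 sits at a limit. The step of a number no higher from compound 1 to compound 3 (the limit leaves the size open) is expected to lie within the scatter, with compound 3 expected to remain at the limit. Compound 3 is accordingly estimated at 150000 nM, with a range from 50000 nM to 400000 nM, and most likely this assay will once more report only a limit.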

Compound 3, half-maximal inhibitory concentration: > 150000 nM
Compound 3: a limit, no number (the forecaster's own chance of this, stated with the estimate: 85%); the middle value lies on the limit itself.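

Among these compounds, no step among compound 1, compound 2 and compound 3 can be read, because all three values are limits rather than numbers: the limit of > 150000 nM in this assay, at which 3 of the 3 values shown sit.
The compounds shown leave open how strongly any of the three acts in this assay and whether 2-nitrophenyl, 3-nitrophenyl or 3-methoxyphenyl on the aromatic nitrogen makes any difference.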